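The compounds below may be only part of what the source reports. "The series", "measured", "known", "first", "only" and "open" are said of these compounds alone.

Measured so far:
- compound 1 `O=C(/C=C/c1ccc(NC(=O)Nc2ccccc2)cc1)NO`: 160 nM
- compound 2 `O=C(CCc1ccc(NC(=O)Nc2ccccc2)cc1)NO`: 1590 nM

In a functional assay on Jurkat cells (Homo sapiens) for cytotoxicity, read by MTT assay, with a stated time of 72 h (on this read-out higher numbers stand for weaker inhibition and lower numbers for stronger inhibition), compound 2 gives 1590 nM, the higher of the two numbers and so the weaker inhibition. Compound 3 `O=C(CCc1ccc(NC(=O)Nc2ccc([N+](=O)[O-])cc2)cc1)NO` differs from compound 2 by one change, nitro in place of hydrogen on an aromatic carbon. Among the compounds with values here, the only measured step is a 9.9-fold higher number from compound 1 to compound 2 (1.00 log units; beyond the scatter), which is beyond the scatter. That step alters the 2-(hydroxycarbamoyl)ethyl chain and not the place now changed, so it gives neither size nor direction for the nitro group. No measurement tests a substituent at this place. With no evidence for a shift, no change beyond the scatter is expected, and the expected step is a 1.2-fold lower number from compound 2 to compound 3 (0.09 log units; within the scatter). For compound 3 the estimated value is 1300 nM, with an expected range from 420 nM to 4000 nM.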

Compound 3, half-maximal inhibitory concentration: 810 nM
Compound 3: middle estimate off by 1.6-fold (0.21 log units), on the high side, within the range that was stated.
By their numbers in this assay, from the lowest: compound 1; then compounds 3 and 2 (each within the scatter of the next).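

Within the data shown here, compound 3 gives the first reading on a substituent at this place, the aromatic carbon para to a large group, and in this assay nitro in place of hydrogen gives a 2.0-fold lower number from compound 2 to compound 3 (0.29 log units; within the scatter). On the 2-(hydroxycarbamoyl)ethyl chain, then, this carbon can carry nitro, with its 3 heavy atoms, without the number leaving the scatter of compound 2. Nothing available explains this result or links it to any property of the nitro group.

From the compounds shown here alone, whether an amine, a methoxy group or a carboxylic acid on the same carbon would also stay within the scatter remains open. So does whether nitro at this place would give a similar result on the 2-(hydroxycarbamoyl)ethenyl chain of compound 1, where the number is already much lower.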